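Moving one chlorine in a small sulfonamide series

The compounds below may be only part of what the source reports. "The series", "measured", "known", "first", "only" and "open" are said of these compounds alone.

Measured so far in a functional assay on cells (leukaemia cell line, Homo sapiens) for inhibition, read by sulforhodamine B assay, with a stated time of 48 h (on this read-out higher numbers stand for weaker inhibition of growth and lower numbers for stronger inhibition of growth), are two compounds:
- compound 1 `Cc1cc(NS(=O)(=O)c2ccc(-c3cnc(C4CC4)o3)cc2)ccc1Cl` gives 216 nM in this test
- compound 2 `Cc1ccc(Cl)c(NS(=O)(=O)c2ccc(-c3cnc(C4CC4)o3)cc2)c1` gives 48.8 nM in this test

Compound 2 has the lower number of the two, meaning stronger growth inhibition. Unmeasured compound 3 `Cc1cc(Cl)cc(NS(=O)(=O)c2ccc(-c3cnc(C4CC4)o3)cc2)c1` differs from it by 3-chloro-5-methylphenyl in place of 2-chloro-5-methylphenyl on a sulfonamide nitrogen. Going by the values given here, the one relevant measured step (a 4.4-fold lower number from compound 1 to compound 2 (0.65 log units; beyond the scatter)) came on gaining 2-chloro-5-methylphenyl, which compound 3 gives up. A higher number of similar size is therefore expected in this assay here. The expected change is a 3.3-fold higher number from compound 2 to compound 3 (0.52 log units; beyond the scatter) by this estimate. The estimated value for compound 3 is 160 nM (range 60 nM to 420 nM).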

Compound 3, concentration for 50% growth inhibition: 175 nM
Estimate against measurement, compound 3: 1.1-fold (0.04 log units) below; low and high end bracket the measured number.
By their numbers in this assay, from the lowest: compound 2; then compounds 3 and 1 (each within the scatter of the next).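

Moving the chlorine to give 3-chloro-5-methylphenyl weakens growth inhibition in this assay (a 3.6-fold higher number from compound 2 to compound 3 (0.55 log units; beyond the scatter)), so the gain belongs to 2-chloro-5-methylphenyl and does not follow from any shift away from 4-chloro-3-methylphenyl. The other two groups remain within the scatter of each other (a 1.2-fold lower number from compound 1 to compound 3 (0.09 log units; within the scatter)). Nothing available explains why this one arrangement stands out. Still open, from the compounds shown here alone, is how 2-fluoro-5-methylphenyl or 2-methoxy-5-methylphenyl would compare with 2-chloro-5-methylphenyl, and whether 2-chlorophenyl alone would keep the gain.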